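Methoxy for Methyl on an Arylpiperazine Amide

A few compounds are considered here, and "the series" means these few. Any claim that something is new, unique, unknown or untested is made for them only; others in the source may bear on it.

Compound 1, `O=C1NC(CCN2CCN(c3ccc4ccccc4c3)CC2)c2ccccc21`: 10 nM
Compound 2, `Cc1ccc(N2CCN(CCC3NC(=O)c4ccccc43)CC2)cc1`: 12.4 nM

In an assay on CHO cells for binding affinity to D(4) dopamine receptor (Homo sapiens) (on this read-out higher numbers stand for weaker inhibition and lower numbers for stronger inhibition), compound 2 gives the higher of the two numbers, yet compound 1 lies within the scatter of it, so the two cannot be ordered. Compound 3, `COc1ccc(N2CCN(CCC3NC(=O)c4ccccc43)CC2)cc1`, differs from compound 2 by methoxy in place of methyl on an aromatic carbon. Among the compounds with values here, no measured pair shows this exchange, so its effect is unknown here. A small step toward weaker binding, if any, is expected, and the step from compound 2 to compound 3 is estimated at a 1.6-fold higher number from compound 2 to compound 3 (0.21 log units; within the scatter). Compound 3 is therefore expected to give 20 nM, with a range from 6 nM to 60 nM.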

Compound 3, inhibition constant: 37.3 nM
Compound 3: the middle estimate sits 1.9-fold (0.27 log units) below what was measured; the measured number falls inside the stated range.
By their numbers in this assay, from the lowest: compounds 1 and 2 (each within the scatter of the next); then compound 3.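

In this assay the exchange of methyl for methoxy on this aromatic carbon, para to a large group, gives a 3.0-fold higher number from compound 2 to compound 3 (0.48 log units; beyond the scatter) and so weakens binding by a modest step beyond the scatter. Within the data shown here, this is the first sign that this position responds to a small change, since the earlier compounds offered no such pair. Nothing measured here explains the shift. Going by these compounds, whether chlorine, a hydroxyl or an amine at the same place would behave more like methyl or like methoxy remains open. So does whether this exchange has the same effect on a different core.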